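Fluoro in place of methyl: compound 3 to compound 4

A few compounds are considered here, and "the series" means these few. Any claim that something is new, unique, unknown or untested is made for them only; others in the source may bear on it.

Compound 3 `Cc1cccc(-n2cc(-c3ccc(NS(=O)(=O)c4c[nH]c(=O)[nH]c4=O)cc3)nn2)c1` gives 6960 nM in a functional assay on A549 cells (Homo sapiens) for antiproliferative activity, read by MTT assay, with a stated time of 24 h; a lower number here means a stronger inhibitor, a higher number a weaker inhibitor. Of the two numbers shown for this assay it is the highest; the nearest is compound 2 `O=c1[nH]cc(S(=O)(=O)Nc2cccc(-c3cn(-c4cccc(Cl)c4)nn3)c2)c(=O)[nH]1`, which in this assay gives 2430 nM, a gap beyond the scatter. Compound 1 `O=c1[nH]cc(S(=O)(=O)Nc2cccc(-c3cn(-c4ccccc4F)nn3)c2)c(=O)[nH]1` in this assay is reported only as a limit, > 20000 nM, not as a number.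

The step to compound 4 `O=c1[nH]cc(S(=O)(=O)Nc2ccc(-c3cn(-c4cccc(F)c4)nn3)cc2)c(=O)[nH]1` is fluoro in place of methyl on an aromatic carbon. Among the measured compounds shown here, only one measured step exists, an at least 8.2-fold lower number from compound 1 to compound 2 (0.91 log units; beyond the scatter), and it touches the same ring of the shared core, yet it exchanges a different pair of groups, fluorine for chlorine with a shift of the substituent pattern, and it starts from a limit (the limit of > 20000 nM in this assay, at which 1 of the 3 values shown sits), so its size cannot be read as a number and it bears only loosely on a methyl-to-fluoro exchange. For the measured compounds named here, no measured step exchanges methyl for fluoro. Compound 2 and compound 3 carry chloro and methyl on that ring and differ beyond the scatter, but they also differ in the substitution of the other ring, so no single effect can be separated from them.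

The change is therefore expected to stay within the scatter, with a 1.2-fold lower number from compound 3 to compound 4 (0.06 log units; within the scatter) as the expected step. Compound 4 is estimated at 6000 nM, with a range from 2500 nM to 15000 nM.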

Compound 4, half-maximal inhibitory concentration: 9980 nM
For compound 4 the middle estimate is 1.7-fold (0.22 log units) below the measured one; measured number inside the range.
By their numbers in this assay, from the lowest: compound 2; then compounds 3 and 4 (each within the scatter of the next). At a limit, above all of these: compound 1.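

In this assay, among the compounds shown here, the exchange of 3-methylphenyl for 3-fluorophenyl gives a 1.4-fold higher number from compound 3 to compound 4 (0.16 log units; within the scatter), the first step with a number at both ends and only one place changed. On this aromatic carbon, methyl and fluoro therefore cannot be told apart in this read-out, and compound 3 and compound 4 stand together within the scatter. The only other step in the series still starts from compound 1, whose entry is a limit and not a number: the limit of > 20000 nM in this assay, at which 1 of the 4 values shown sits.

Still open, from the compounds shown here alone, is whether any group at this position moves the number beyond the scatter; an amine, a carboxylic acid or a methoxy group on the same carbon, with the rest of compound 4 kept, would answer that. Also open, going by these compounds, is what chloro does in place of fluoro on compound 4: compound 2 carries a chloro group and gives 2430 nM, but it differs from compound 3 and compound 4 in more than one place, so that value cannot be assigned to the chloro group alone.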